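Acetoxymethyl in place of carboxy on the shared core

A few compounds are considered here, and "the series" means these few. Any claim that something is new, unique, unknown or untested is made for them only; others in the source may bear on it.

Of the compounds shown here, two on the shared core have been read so far in a functional assay on KBVIN cells (Homo sapiens) for cytotoxicity, read by sulforhodamine B assay, with a stated time of 3 days; a lower number here means that less compound is needed, a higher number that more compound is needed for the effect. Compound 1 (`CCOCc1c(C)coc1-c1ccc2c(c1OC)CCCC2(C)C`) gives 16.5 uM. Compound 2 (`COc1c(-c2occ(C)c2C(=O)O)ccc2c1CCCC2(C)C`) gives 47.8 uM, the higher of the two numbers. Compound 3 (`COc1c(-c2occ(C)c2COC(C)=O)ccc2c1CCCC2(C)C`) has not yet been measured. It carries acetoxymethyl in place of the carboxy of compound 2, on an aromatic carbon of a five-membered aromatic ring with 1 oxygen: acetoxymethyl in place of carboxy on an aromatic carbon. Among the compounds with values here, one measured step bears on this change: a 2.9-fold higher number from compound 1 to compound 2 (0.46 log units; beyond the scatter). That step is modest but beyond the scatter, and in it carboxy takes the place of ethoxymethyl. Acetoxymethyl is structurally nearer to ethoxymethyl than to carboxy, so that step can be read in reverse, with caution, since it is a single step and no acetoxymethyl compound has a reading yet. A modest move toward a lower number in this assay is therefore expected, similar to that step or slightly smaller. The estimated step is a 2.4-fold lower number from compound 2 to compound 3 (0.38 log units; beyond the scatter). For compound 3 the expected value is 20 uM, with an estimated range of 9 uM to 45 uM.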

Compound 3, concentration for half-maximal effect: 24.9 uM
Compound 3: the middle estimate sits 1.2-fold (0.10 log units) below what was measured; the measured number falls inside the stated range.
By their numbers in this assay, from the lowest: compounds 1, 3 and 2 (each within the scatter of the next, the first and the last beyond it).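

In this assay, acetoxymethyl in place of carboxy on an aromatic carbon gives a 1.9-fold lower number from compound 2 to compound 3 (0.28 log units; within the scatter), and acetyl in place of ethyl on an oxygen on a saturated carbon gives a 1.5-fold higher number from compound 1 to compound 3 (0.18 log units; within the scatter). Compound 3 therefore cannot be separated from either compound 1 or compound 2, even though those two remain apart by a 2.9-fold higher number from compound 1 to compound 2 (0.46 log units; beyond the scatter). The earlier step suggested a clear split between ethoxymethyl and carboxy at this position, but acetoxymethyl fills the gap without resolving into either side, and no supporting data explain these readings.

Open, from the compounds shown here alone, is whether an aminomethyl group, a primary amide or a longer ether chain at this position would move the number beyond the scatter in either direction, relative to the three groups read so far. Also open is whether a free hydroxymethyl group would read with compound 3 or apart from it, and whether the pattern among these three compounds carries over to any other cell assay.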